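The source may hold more compounds than are shown below. What is called first, only, known or untested is meant among the compounds shown, and "the series" means these compounds.

Measured compounds in an ADME assay on Caco-2 cells (Homo sapiens) for permeability, read by LC-MS, in the apical to basolateral direction, with a stated time of 60 min, at pH 6.5; on this read-out lower numbers stand for lower permeability and higher numbers for higher permeability:
compound 1 `O=C(NCc1cc(Cl)ccc1-n1cnnn1)[C@@H]1[C@H]2C[C@H]2CN1C(=O)[C@H](O)CC1CC1` gives 3.4 10^-6 cm/s
compound 2 `O=C(O[C@@H](C(=O)N1N=CC[C@H]1C(=O)NCc1cc(Cl)ccc1-n1cnnn1)c1ccc(F)cc1)c1ccccc1` gives 43 10^-6 cm/s
compound 3 `CC1(C[C@@H](O)C(=O)N2N=CC[C@H]2C(=O)NCc2cc(Cl)ccc2-n2cnnn2)CC1` gives 9.5 10^-6 cm/s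

Compound 1 stands lowest of the three numbers in this assay. Its nearest neighbour is compound 3, whose value lies beyond the scatter above it, and the furthest is compound 2, which stands well beyond the scatter higher still. Compound 1 and compound 3 share the same hydroxy acid tail bearing a small saturated carbocycle, and differ in their cores; compound 2 carries an aromatic ring and an ester at the corresponding position.

The next compound follows compound 1 on the saturated chain carbon bound to a carbonyl carbon and an oxygen on a saturated carbon. Compound 4 `O=C(NCc1cc(Cl)ccc1-n1cnnn1)[C@@H]1[C@H]2C[C@H]2CN1C(=O)[C@H](O)c1ccccc1` is made from compound 1 by phenyl in place of cyclopropylmethyl on a saturated chain carbon bound to a carbonyl carbon and an oxygen on a saturated carbon while the core and the tetrazolyl-chlorobenzylamide part are unchanged. Among the measured compounds shown here, no measured pair shows exactly this change, so the size of the step is not known from the data. Given that compound 2, the only measured compound with an aromatic ring in this tail, gives 43 10^-6 cm/s in this assay, a modest rise is expected, with the step from compound 1 to compound 4 estimated at a 1.8-fold higher number from compound 1 to compound 4 (0.25 log units; within the scatter), which may lie within the scatter. Compound 4 is therefore expected to give about 6 10^-6 cm/s in this assay, within the range 2.5 10^-6 cm/s to 15 10^-6 cm/s.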

Compound 4, apparent permeability: 12 10^-6 cm/s
Estimate against measurement, compound 4: 2.0-fold (0.30 log units) below, and the stated range covers the measured number.
By their numbers in this assay, from the lowest: compound 1; then compounds 3 and 4 (each within the scatter of the next); then compound 2.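

In this assay the exchange of cyclopropylmethyl for phenyl on a saturated chain carbon bound to a carbonyl carbon and an oxygen on a saturated carbon gives a 3.5-fold higher number from compound 1 to compound 4 (0.55 log units; beyond the scatter) with the core and the tetrazolyl-chlorobenzylamide part unchanged. This is the first pair among the compounds shown that differs in one place only, so it shows for the first time that the read-out responds to this position alone, by a step beyond the usual scatter, whereas the earlier compounds also differed in their cores. The study offers no measurement that accounts for the step, so its cause remains unassigned.

Among the compounds shown here, the single exchange replaces a saturated group with an aromatic ring and also changes the number of heavy atoms, so it cannot tell whether the step follows the aromatic ring or the larger group, a question that cyclohexyl or pyridyl at the same place would address. Also open, on these data alone, is whether the same exchange would give a step of similar size on the core of compound 3.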